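This account rests on a few compounds, and the source may have more. Where it says the series, first, only, none or still open, it means among the compounds named here.

In a functional assay on EC9706 cells (Homo sapiens) for antiproliferative activity, read by MTT assay, with a stated time of 72 h (on this read-out lower numbers stand for stronger inhibition and higher numbers for weaker inhibition), compound 1 `C/C(=N\NC(=O)c1cccc(S(=O)(=O)N2CCOCC2)c1)c1cccc(O)c1` gives > 100000 nM, which is a limit of the assay. Compound 2 `CCN(CC)c1ccc(/C=N/NC(=O)c2cccc(S(=O)(=O)N3CCOCC3)c2)c(O)c1` gives 920 nM and compound 3 `COc1ccc(/C=N/NC(=O)c2cccc(S(=O)(=O)N3CCOCC3)c2)c(O)c1` gives 1090 nM, so compound 3 stands level with compound 2 within the scatter. Compound 4 `O=C(N/N=C/c1cc(Br)cc(Br)c1O)c1cccc(S(=O)(=O)N2CCOCC2)c1` differs from compound 3 as follows: 3,5-dibromo-2-hydroxyphenyl in place of 2-hydroxy-4-methoxyphenyl on a carbon with a double bond to nitrogen. In words, 3,5-dibromo-2-hydroxyphenyl stands in place of 2-hydroxy-4-methoxyphenyl on a carbon with a double bond to nitrogen. Within the data shown here, the one measured step bearing on this change is a 1.2-fold higher number from compound 2 to compound 3 (0.07 log units; within the scatter), with methoxy in place of diethylamino on an aromatic carbon. From the compounds shown here alone, on that single small step, nothing beyond the scatter is expected in this assay, and the direction stays open. The expected step is a 1.6-fold lower number from compound 3 to compound 4 (0.19 log units; within the scatter). For compound 4 the estimate is 700 nM, with an expected range of 150 nM to 3000 nM.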

Compound 4, half-maximal inhibitory concentration: 2440 nM
For compound 4 the middle estimate is 3.5-fold (0.54 log units) below the measured one; the range from low to high includes it.
By their numbers in this assay, from the lowest: compounds 2 and 3 (each within the scatter of the next); then compound 4. At a limit, above all of these: compound 1.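

Replacing 2-hydroxy-4-methoxyphenyl with 3,5-dibromo-2-hydroxyphenyl on the carbon with a double bond to nitrogen gives a 2.2-fold higher number from compound 3 to compound 4 (0.35 log units; beyond the scatter), a modest change in this assay. Unlike the earlier step between compound 2 and compound 3, this step lies beyond the scatter, so the ring substituents at this place can register in the read-out, even with the hydroxy kept in the name of both groups. Nothing measured here gives a cause for this step.

The compounds shown leave open whether the loss of methoxy or the entry of bromine carries the step. From the compounds shown here alone, how a carboxylic acid or an amine on this ring would read also remains open.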